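Chloro for hydrogen on the cap: compound 3 to compound 4

The source may hold more compounds than are shown below. What is called first, only, known or untested is meant among the compounds shown, and "the series" means these compounds.

Three compounds of this series have been run in an assay on isolated protein for inhibition of protein deacetylase HDAC6 (Homo sapiens), read by fluorescence, with a stated time of 2 h; a higher number here means a weaker inhibitor, a lower number a stronger inhibitor. Compound 1 `CCCNNC(=O)c1ccc(CNC(=O)c2ccc3ccncc3c2)cc1` sits at the assay limit, > 10000 nM. Compound 2 `CCCNNC(=O)c1ccc(CNC(=O)c2cc3ccccc3[nH]2)cc1` likewise returns only the limit, > 10000 nM. Compound 3 `CCCNNC(=O)c1ccc(CNC(=O)c2cc3ccccc3o2)cc1` also gives the limit, > 10000 nM. Going by the values given here, compound 3 therefore stands nowhere apart from the others: every value shown is a limit, as the limit of > 10000 nM in this assay, at which 3 of the 3 values shown sit, records, and no step between measured compounds can be sized. Compound 4 `CCCNNC(=O)c1ccc(CNC(=O)c2cc3cc(Cl)ccc3o2)cc1` differs from compound 3 by chloro in place of hydrogen on an aromatic carbon. Among the compounds with values here, with no measured step to rest on, the expected shift in this assay is a step that the limit leaves unreadable from compound 3 to compound 4, nothing beyond the scatter and in no set direction. Compound 4 is accordingly estimated at 15000 nM, within 5000 nM to 50000 nM, most likely again a limit rather than a number.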

Compound 4, half-maximal inhibitory concentration: > 10000 nM
Compound 4 gave a limit, no number (the forecaster's own chance of this, stated with the estimate: 80%); the middle value does not contradict the limit.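

No step can be read between compound 3 and compound 4, because both return only a limit: the limit of > 10000 nM in this assay, at which 4 of the 4 values shown sit. The compounds shown leave open whether any cap on the shared core gives a readable value, and what chloro in place of hydrogen does.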